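Sulfone anilide series: pyrimidinyl replacement for methoxyphenyl

The source may report more compounds than this note shows. Statements on the series, on what has been measured and on what is new or still open speak of the compounds shown alone.

Working notes. The series shares an amide-linked trifluoromethyl carbinol on an anilide core. Compound 1 `CC(O)(C(=O)Nc1ccc(S(=O)(=O)c2ccccc2)c(O)c1)C(F)(F)F` is measured in a functional assay (Cavia porcellus) with sulfonylurea receptors; K-ATP channels (Homo sapiens) as the target (a higher number here means a weaker inhibitor, a lower number a stronger inhibitor), at 430 nM. Compound 2 `COc1ccc(S(=O)(=O)c2ccc(NC(=O)C(C)(O)C(F)(F)F)cc2)cc1` gives in this assay only a limit, > 30000 nM, not a number. Compound 3 `CC(O)(C(=O)Nc1ccc(C(=O)c2ccccc2)cc1Br)C(F)(F)F` likewise returns a limit in this assay, > 30000 nM. So compound 2 sits at the weak end of what is shown, sharing the limit of > 30000 nM in this assay, at which 2 of the 3 values shown sit, with compound 3, while compound 1 alone carries a number.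

Compound 4 `CC(O)(C(=O)Nc1ccc(S(=O)(=O)c2cncnc2)cc1)C(F)(F)F` is not yet measured. Its change from compound 2 is pyrimidin-5-yl in place of 4-methoxyphenyl on a sulfonyl sulfur. Within the data shown here, no pair of measured compounds isolates this change, so its size is open. With compound 2 already at the limit, the step can only go toward stronger inhibition or stay at the limit; a modest move toward stronger inhibition is expected, an at least 2.0-fold lower number from compound 2 to compound 4 (0.30 log units; that floor lies within the scatter), but a further limit is quite possible. In this assay compound 4 is estimated at 15000 nM, within 2000 nM to 60000 nM.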

Compound 4, half-maximal inhibitory concentration: > 30000 nM
Compound 4 ended at the assay's limit; the forecaster's own chance of this, stated with the estimate: 50%; middle value at least 2.0-fold (0.30 log units) away from the limit.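

Compound 2 and compound 4 both sit at a limit rather than a number, so no step between them can be read: the limit of > 30000 nM in this assay, at which 3 of the 4 values shown sit.

Going by these compounds, whether pyrimidin-5-yl in place of 4-methoxyphenyl on a sulfonyl sulfur changes inhibition at all, and by how much, stays open.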